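The source may hold more compounds than are shown below. What is called first, only, known or untested is meant among the compounds shown, and "the series" means these compounds.

Compound 1 `O=c1ccn(COCCO)c(=O)[nH]1` gives > 400 ug/mL in a functional assay (Oryctolagus cuniculus) for inhibition (on this read-out lower numbers stand for stronger inhibition and higher numbers for weaker inhibition), a limit of the assay rather than a number.
Compound 2 `Nc1nc2c(nc(I)n2COCCO)c(=O)[nH]1` gives >= 250 ug/mL in this assay, again a limit of the assay rather than a number.

Compound 2 therefore stands at a limit, not at a measured number: the limit of >= 250 ug/mL in this assay, at which 1 of the 2 values shown sits. Within the data shown here, the one further value shown, for compound 1, is also a limit: the limit of > 400 ug/mL in this assay, at which 1 of the 2 values shown sits. Among the measured compounds shown here, both values say only that inhibition is weak up to the concentrations tested, so no step between measured compounds can be read from them, and no direction of change can be drawn from this pair.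

Compound 3 `CNc1nc2c(=O)[nH]c(N)nc2n1COCCO` is not yet measured. It differs from compound 2 in one place: methylamino in place of iodo on an aromatic carbon. The other parts, including the (2-hydroxyethoxy)methyl group, are kept.

For the measured compounds named here, with both measured values sitting at limits, there is no measured step to lean on. The expectation is a step from compound 2 to compound 3 of a number no higher from compound 2 to compound 3 (the limit leaves the size open) in this assay, that is, nothing clearly beyond the usual scatter. Compound 3 is estimated at 250 ug/mL, with a range from 50 ug/mL to 800 ug/mL, and most likely the assay will again report only a limit.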

Compound 3, concentration for 50% inhibition: > 400 ug/mL
Compound 3: only a limit was reported (the forecaster's own chance of this, stated with the estimate: 70%); middle value at least 1.6-fold (0.20 log units) from the limit.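

Compound 2 and compound 3 both stand at limits of this assay rather than at numbers, so no step can be read for the change from iodo to methylamino. The compounds shown leave open how strongly any of them inhibits, and whether another group at this place would give a measurable value.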